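Side-chain replacement at the amino acid position: compound 3

The source may hold more compounds than are shown below. What is called first, only, known or untested is meant among the compounds shown, and "the series" means these compounds.

Measured compounds:
compound 1, `NC(=O)CC[C@H](NC(=O)CN(c1nc(Cl)nc2c1ncn2C1CCCCO1)C1CC1)C(=O)OCc1ccccc1` — 37.8% in a functional assay on the whole organism with Mus musculus as the target, with a stated time of 90 min, at a dose of 25 umol/kg by the oral route; a higher number here means a stronger effect of the compound at the dose given, a lower number a weaker effect
compound 2, `CC(C)C[C@H](NC(=O)CN(c1nc(Cl)nc2c1ncn2C1CCCCO1)C1CC1)C(=O)OCc1ccccc1` — 28.2% in this assay

Within the data shown here, compound 2 gives the smaller of the two numbers in this assay; its only neighbour is compound 1, and the gap between them is within the scatter, so the two cannot be ranked. Compound 3, `CC(C)(C)OC(=O)NCCCC[C@H](NC(=O)CN(c1nc(Cl)nc2c1ncn2C1CCCCO1)C1CC1)C(=O)OCc1ccccc1`, is not yet measured in this assay. It differs from compound 2 in one place: 3-((tert-butoxycarbonyl)amino)propyl in place of isopropyl on a saturated chain carbon, two bonds along the chain from an amide-type nitrogen and a carbonyl carbon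

Among the measured compounds shown here, the only measured step at this position is a number 9.6 percentage points lower from compound 1 to compound 2 (within the scatter), which stayed within the scatter although the side chain changed. For the measured compounds named here, no step with a group like the entering one has been measured, so the expectation rests on that single step alone. A move of similar size, not beyond the scatter, is expected for compound 3: a number 4.8 percentage points higher from compound 2 to compound 3 (within the scatter). Compound 3 is therefore estimated at 33% in this assay, with a range from 15% to 52%.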

Compound 3, a percentage reported as activity, at one dose (the size of the read-out at that dose, not a potency): 32.9%
For compound 3 the middle estimate is 0.1 percentage points above the measured one; the range from low to high includes it.
By their numbers in this assay, from the lowest: compounds 2, 3 and 1 (each within the scatter of the next).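

In this assay, this position takes a side chain of 11 heavy atoms in place of one of 3 with no step beyond the scatter: replacing isopropyl with 3-((tert-butoxycarbonyl)amino)propyl gives a number 4.7 percentage points higher from compound 2 to compound 3 (within the scatter). Replacing carbamoyl with 2-((tert-butoxycarbonyl)amino)ethyl, further out on the chain, gives a number 4.9 percentage points lower from compound 1 to compound 3 (within the scatter), so the three side chains shown cannot be ranked in this assay. No measurement is available that bears on the reason for this result.

Going by these compounds, it remains open whether a free amine at the end of the chain, in place of the tert-butoxycarbonyl-protected nitrogen, would give a step beyond the scatter. The same holds for a carboxylic acid at that chain end and for a side chain carrying a phenyl ring.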